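A Chlorine Added to the Anilide Ring of Compound 1

The source may report more compounds than this note shows. Statements on the series, on what has been measured and on what is new or still open speak of the compounds shown alone.

Compound 1 `Cc1nc(C(NC(=O)C(=O)Nc2ccc(F)cc2)C2CCCCN2)sc1CCO` was tested in an ADME assay on MT2 cells (Homo sapiens) for cytotoxicity, read by XTT assay, with a stated time of 4 days (on this read-out lower numbers stand for higher toxicity in this test and higher numbers for lower toxicity in this test), where compound 1 gives 109000 nM. Among the two plain numbers in this set, compound 1 stands highest; its nearest neighbour is compound 3 `Cc1nc(C(NC(=O)C(=O)Nc2ccc(Cl)cc2)C2CCCN2)sc1CCO`, which in this assay gives 42000 nM. Compound 2 `Cc1nc(C(NC(=O)C(=O)NC2CCCCCC2)C2CCCCN2)sc1CO` returned only a limit in this assay, namely > 90000 nM. Compound 4 `Cc1nc(C(NC(=O)C(=O)Nc2ccc(Cl)c(F)c2)C2CCCCN2)sc1CCO` has not yet been tested. It differs from compound 1 in one place: 4-chloro-3-fluorophenyl in place of 4-fluorophenyl on an amide-type nitrogen. For the measured compounds named here, no single-change step between measured compounds is available here, so only a rough expectation can be formed. For compound 4 a modest move toward higher toxicity is expected, a 1.6-fold lower number from compound 1 to compound 4 (0.19 log units; within the scatter), staying near the scatter. The estimated value for compound 4 in this assay is 70000 nM, within a range of 30000 nM to 150000 nM.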

Compound 4, half-maximal cytotoxic concentration: > 41000 nM
Compound 4 gave a limit, no number; the forecaster's own chance of this, stated with the estimate: 30%; the middle value is on the limit's open side.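

In this assay compound 4 gives only a limit of > 41000 nM and no number, so its step from compound 1 cannot be read. From the compounds shown here alone, whether 4-chloro-3-fluorophenyl in place of 4-fluorophenyl changes the cytotoxicity reading at all stays open.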